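Notes on a methyl-to-fluoro change in the series

The source may hold more compounds than are shown below. What is called first, only, known or untested is meant among the compounds shown, and "the series" means these compounds.

Values in a functional assay on PC-3 cells (Homo sapiens) for inhibition, read by MTT assay, with a stated time of 48 h; on this read-out higher numbers stand for weaker inhibition and lower numbers for stronger inhibition:
- compound 1 `COc1ccc(-n2c(SCc3ccc(F)cc3)nnc2-c2cc(OC)c(OC)c(OC)c2)cc1` gives 35000 nM
- compound 2 `COc1cc(-c2nnc(SCc3ccc(C)cc3)n2-c2ccc(N(C)C)cc2)cc(OC)c1OC` gives 37300 nM

Compound 2, at 37300 nM, stands level with compound 1, as the two numbers lie within the scatter of each other. The next entry is compound 3 `COc1cc(-c2nnc(SCc3ccc(F)cc3)n2-c2ccc(N(C)C)cc2)cc(OC)c1OC`, which differs from compound 2 in one place: fluoro in place of methyl on an aromatic carbon. This is fluoro in place of methyl on an aromatic carbon, para to a large group, so that (4-methylbenzyl)sulfanyl becomes (4-fluorobenzyl)sulfanyl.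

Among the compounds with values here, no measured pair isolates this change, so its size cannot be read directly from the data. Within the data shown here, the only guide is the close agreement of the two measured compounds, compound 1 at 35000 nM and compound 2 at 37300 nM. No step beyond the scatter is therefore expected in this assay. The estimated change is a 1.2-fold lower number from compound 2 to compound 3 (0.07 log units; within the scatter), which stays within the scatter. For compound 3 the expected value is 32000 nM, with an estimated range of 14000 nM to 70000 nM.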

Compound 3, half-maximal inhibitory concentration: 46500 nM
Compound 3: middle estimate off by 1.5-fold (0.16 log units), on the low side; the measured number falls inside the stated range.
By their numbers in this assay, from the lowest: compounds 1, 2 and 3 (each within the scatter of the next).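

In this assay, the pair that isolates fluoro in place of methyl on an aromatic carbon, para to a large group, gives a 1.2-fold higher number from compound 2 to compound 3 (0.10 log units; within the scatter) and so shows no step beyond the scatter for turning (4-methylbenzyl)sulfanyl into (4-fluorobenzyl)sulfanyl on this core. The same entry also supplies a second single-place comparison, dimethylamino in place of methoxy on an aromatic carbon, with a 1.3-fold higher number from compound 1 to compound 3 (0.12 log units; within the scatter) and likewise no step beyond the scatter, so neither of the two places varied here has yet moved the number in this assay by more than repeat measurements would. No supporting measurement accompanies these numbers to account for either result.

Still open, on these data alone, is whether a group of a different kind at the place para to a large group, such as a carboxylic acid, an amine or a longer chain in place of the methyl, would produce a step beyond the scatter. Also open, as far as these compounds go, is whether fluoro and methyl would stand equally level with methoxy in place of dimethylamino on the other aromatic ring.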